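A few compounds are considered here, and "the series" means these few. Any claim that something is new, unique, unknown or untested is made for them only; others in the source may bear on it.

In a functional assay on CCRF-CEM cells (Homo sapiens) for antiproliferative activity, with a stated time of 72 h (on this read-out higher numbers stand for weaker inhibition and lower numbers for stronger inhibition), compound 1 `OC[C@H]1O[C@@H](n2cnc3c(NCc4cccc(F)c4)ncnc32)[C@H](O)[C@@H]1O` gives 4000 nM and compound 2 `OC[C@H]1O[C@@H](n2cnc3c(NCc4ccccc4Cl)ncnc32)[C@H](O)[C@@H]1O` gives 14500 nM, so compound 2 holds the higher of the two numbers. Compound 3 `Cc1ccc(CNc2ncnc3c2ncn3[C@@H]2O[C@H](CO)[C@@H](O)[C@H]2O)cc1` departs from compound 2 by one change: 4-methylphenyl in place of 2-chlorophenyl on a saturated chain carbon bound to a nitrogen on an aromatic ring. Among the compounds with values here, the only measured step bearing on this is a 3.6-fold higher number from compound 1 to compound 2 (0.56 log units; beyond the scatter), a modest step that also exchanged one substituted phenyl for another at the same place. A step of that size or smaller is therefore expected, towards a lower number. The expected step is a 1.8-fold lower number from compound 2 to compound 3 (0.26 log units; within the scatter). The estimate for compound 3 is 8000 nM, with an expected range from 2500 nM to 25000 nM.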

Compound 3, half-maximal inhibitory concentration: > 166000 nM
Compound 3: a limit, no number; the forecaster's own chance of this, stated with the estimate: 10%; middle value at least 20-fold (1.31 log units) from the limit.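

In this assay compound 3 carries a limit and not a number: the limit of > 166000 nM in this assay, at which 1 of the 3 values shown sits. Even so, the change gives an at least 11-fold higher number from compound 2 to compound 3 (1.05 log units; beyond the scatter), and the comparison with the other measured compound gives an at least 41-fold higher number from compound 1 to compound 3 (1.61 log units; beyond the scatter). Within the data shown here, both steps are large, while the only earlier change at this place was modest, so the choice of substituted phenyl here can matter far more than compound 1 and compound 2 alone showed. The compounds shown do not tell whether the methyl group itself or its position in 4-methylphenyl goes with this rise. On these data alone, how a methoxy group or an amine on the phenyl ring would read also stays open.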